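From 4-fluorophenyl to 3-fluorophenyl in compound 2

This account rests on a few compounds, and the source may have more. Where it says the series, first, only, none or still open, it means among the compounds named here.

In a functional assay on U-87MG ATCC cells for inhibition, with U-87 MG (Homo sapiens) as the target, read by MTT assay, with a stated time of 72 h (on this read-out higher numbers stand for weaker inhibition and lower numbers for stronger inhibition), compound 1 `Oc1c(C(Nc2ccccn2)c2ccccc2Cl)ccc2cccnc12` gives 9400 nM and compound 3 `COc1cc(C(Nc2ccc(C)cn2)c2ccc3cccnc3c2O)cc(OC)c1O` gives 7400 nM and these two values lie within the scatter of each other. Compound 2 `Cc1ccnc(NC(c2ccc(F)cc2)c2ccc3cccnc3c2O)c1` gives > 10000 nM as a limit of the assay and not a number. Compound 4 `Cc1ccnc(NC(c2cccc(F)c2)c2ccc3cccnc3c2O)c1` carries the change 3-fluorophenyl in place of 4-fluorophenyl on a saturated chain carbon bound to an aromatic carbon and a nitrogen on an aromatic ring in which 3-fluorophenyl stands in place of 4-fluorophenyl on a saturated chain carbon bound to an aromatic carbon and a nitrogen on an aromatic ring. Among the measured compounds shown here, no measured pair shows such a change, so in this assay no step beyond the scatter is expected. The expected step is an at least 1.1-fold lower number from compound 2 to compound 4 (0.04 log units; that floor lies within the scatter) and it carries no clear direction. Compound 4 is estimated at 9000 nM with an expected range of 4500 nM to 16000 nM on this read-out.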

Compound 4, half-maximal inhibitory concentration: 9200 nM
Estimate against measurement, compound 4: 1.0-fold (0.01 log units) below; the range from low to high includes it.
By their numbers in this assay, from the lowest: compounds 3, 4 and 1 (each within the scatter of the next). At a limit, above all of these: compound 2.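

In this assay, 3-fluorophenyl in place of 4-fluorophenyl on a saturated chain carbon bound to an aromatic carbon and a nitrogen on an aromatic ring gives an at least 1.0-fold lower number from compound 2 to compound 4 (0.03 log units; that floor lies within the scatter), the first step read at this place. Compound 2 gives > 10000 nM, a limit of the assay and not a number. The true size of the step therefore stays unresolved because of where compound 2 sits: the limit of > 10000 nM in this assay, at which 1 of the 4 values shown sits.

Open, on these data alone, is whether a different group on this phenyl ring, such as an amine or a carboxylic acid, would give a step beyond the scatter.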